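The compounds below may be only part of what the source reports. "The series", "measured", "known", "first", "only" and "open" are said of these compounds alone.

Measured so far:
compound 1 `N/C(=N\NC(=S)N1CCOCC1)c1ccccn1`: 14%
compound 2 `N/C(=N\NC(=S)N1CCSCC1)c1ccccn1`: 87.8%

Among the measured compounds shown here, in a functional assay on A-375 cells (Homo sapiens) for cytotoxicity, read by MTT assay, with a stated time of 72 h, tested at 100 uM (a higher number here means more inhibition of growth at the concentration tested, a lower number less inhibition of growth), compound 1 stands lowest of the two numbers; compound 2 sits far above it, the one measured step being a number 73.8 percentage points higher from compound 1 to compound 2 (beyond the scatter). Compound 3 `N/C(=N\NC(=S)N1CCOCC1)c1ccc(F)cn1` differs from compound 1 by fluoro in place of hydrogen on an aromatic carbon. For the measured compounds named here, that measured step concerns the group on the thiocarbonyl carbon, not the aromatic ring, so no measured step bears on this change. Compound 3 is therefore expected to show no step beyond the scatter, a number 4 percentage points higher from compound 1 to compound 3 (within the scatter). Compound 3 is estimated at 18%, within a range from 4% to 45%.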

Compound 3, percent growth inhibition at one concentration: 86.2%
For compound 3 the middle estimate is 68.2 percentage points below the measured one; the measured number lies above the stated range.
By their numbers in this assay, from the lowest: compound 1; then compounds 3 and 2 (each within the scatter of the next).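

In this assay, an aromatic carbon two atoms from the ring nitrogen proves highly responsive: fluoro in place of hydrogen there gives a number 72.2 percentage points higher from compound 1 to compound 3 (beyond the scatter), a large step from a single added atom. A morpholin-4-yl group on the thiocarbonyl carbon therefore does not by itself hold growth inhibition low, and a change on the ring can also lift it. No evidence is available to explain this step. On these data alone, whether chloro, methoxy or an amine at this carbon would match fluoro remains open, as does the effect of fluoro on compound 2.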